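Compound 3 to compound 4: chloro in place of methyl

The compounds below may be only part of what the source reports. "The series", "measured", "known", "first", "only" and "open" are said of these compounds alone.

In a functional assay on OVCAR-3 cells (Homo sapiens) for antiproliferative activity, read by MTT assay, with a stated time of 24 h (on this read-out higher numbers stand for weaker inhibition and lower numbers for stronger inhibition), compound 3 `Cc1ccccc1C(=O)NNC(=O)c1ccccc1NS(=O)(=O)c1cnc(O)nc1O` gives > 20000 nM, which is a limit and not a number. Two measured neighbours give numbers: compound 1 `O=C(NNc1ccccc1Cl)c1ccccc1NS(=O)(=O)c1cnc(O)nc1O` gives 14100 nM, and compound 2 `O=C(NNc1cccc(Cl)c1)c1ccccc1NS(=O)(=O)c1cnc(O)nc1O` gives 5520 nM.

Compound 4 `O=C(NNC(=O)c1ccccc1NS(=O)(=O)c1cnc(O)nc1O)c1ccccc1Cl` differs from compound 3 by chloro in place of methyl on an aromatic carbon, with chloro in place of methyl on an aromatic carbon, ortho to a large group. Among the compounds with values here, no measured step makes this exchange, so the evidence is indirect. The (2-methylphenyl)carbonyl group enters in an at least 1.4-fold higher number from compound 1 to compound 3 (0.15 log units; that floor lies within the scatter) and in an at least 3.6-fold higher number from compound 2 to compound 3 (0.55 log units; beyond the scatter). Moving chlorine gives a 2.6-fold lower number from compound 1 to compound 2 (0.41 log units; beyond the scatter), a modest step, and it is the only measured step between two chlorine-bearing compounds. A step of that modest size at most is therefore expected here, and most likely none beyond the scatter, with weak inhibition retained.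

The expected step is an at least 1.1-fold lower number from compound 3 to compound 4 (0.04 log units; that floor lies within the scatter). Compound 4 is estimated at 18000 nM, with an expected range of 9000 nM to 32000 nM. A reading that reports only a limit is about as likely as a number.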

Compound 4, half-maximal inhibitory concentration: 18200 nM
Estimate against measurement, compound 4: 1.0-fold (0.00 log units) below, within the range that was stated.
By their numbers in this assay, from the lowest: compound 2; then compounds 1 and 4 (each within the scatter of the next). At a limit, above all of these: compound 3.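

In this assay, chloro in place of methyl on this aromatic carbon, ortho to a large group, gives an at least 1.0-fold lower number from compound 3 to compound 4 (0.04 log units; that floor lies within the scatter), so the size of the exchange cannot be fixed against the limit: the limit of > 20000 nM in this assay, at which 1 of the 4 values shown sits. With the chlorine position held, adding a carbonyl to the 2-chlorophenyl group gives a 1.3-fold higher number from compound 1 to compound 4 (0.11 log units; within the scatter), so this change makes no difference beyond the scatter in this pair. (2-Chlorophenyl)carbonyl in place of 3-chlorophenyl gives a 3.3-fold higher number from compound 2 to compound 4 (0.52 log units; beyond the scatter), and the 3-chlorophenyl group remains the only one here set clearly apart from the others.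

From the compounds shown here alone, whether a (3-chlorophenyl)carbonyl group would keep the lower number stays open. So does whether fluoro or methoxy in place of chloro on this aromatic carbon would give a reading different from the chloro compound.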